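The source may report more compounds than this note shows. Statements on the series, on what has been measured and on what is new or still open speak of the compounds shown alone.

Measured so far:
- compound 1 `Cc1cc(C(=O)N[C@H]2CCN(Cc3ccc(OCCCN(C)C)cc3)C2)ccc1Cl`: 631 nM
- compound 2 `COc1ccc(C(=O)N[C@H]2CCN(Cc3ccc(OCCCN(C)C)cc3)C2)cc1OC`: < 10000 nM
- compound 3 `Cc1cc(C(=O)N[C@H]2CCN(Cc3ccc(OCCCN(C)C)cc3)C2)ccc1Br`: 631 nM

Working notes on the series. In an assay on HEK293 cells for binding affinity to Urotensin-2 receptor (Homo sapiens), read by radioligand binding (a higher number here means a weaker inhibitor, a lower number a stronger inhibitor), compound 1 gives 631 nM. Compound 3 carries bromo in place of chloro on an aromatic carbon and gives 631 nM in this assay, so no change at the digits printed from compound 1 to compound 3 (within the scatter): compound 3 stands level with compound 1 at the digits shown. The value of compound 2 is a limit of this assay, (the limit of < 10000 nM in this assay, at which 1 of the 3 values shown sits), and compound 2 gives < 10000 nM. Because of that limit the aryl exchange a step that the limit leaves unreadable from compound 1 to compound 2 and likewise a step that the limit leaves unreadable from compound 2 to compound 3 cannot be sized.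

Compound 4 `CN(C)CCCOc1ccc(CN2CC[C@H](NC(=O)c3cccs3)C2)cc1` is not yet measured. It differs from compound 3 by thiophen-2-yl in place of 4-bromo-3-methylphenyl on a carbonyl carbon. Going by the values given here, the only readable measured step, the halogen swap from compound 1 to compound 3, touches the same carbonyl-bound ring but not its replacement; the two steps that do exchange that ring end in a limit and give no size. So the expectation for compound 4 rests on thin ground; a weakening step is expected, a 4.0-fold higher number from compound 3 to compound 4 (0.60 log units; beyond the scatter), with wide uncertainty. Compound 4 is estimated at 2500 nM in this assay, in the range 500 nM to 10000 nM.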

Compound 4, inhibition constant: < 10000 nM
Compound 4 was reported as a limit; the forecaster's own chance of this, stated with the estimate: 30%; the middle value lies beyond the limit too.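

In this assay compound 4 gives < 10000 nM, which is a limit. Going by these compounds alone, no new step from compound 1, compound 2 or compound 3 to compound 4 can be read: the limit of < 10000 nM in this assay, at which 2 of the 4 values shown sit. The compounds shown leave open the size of any step from 4-bromo-3-methylphenyl to thiophen-2-yl on the carbonyl carbon.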